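Working notes: fluoro in place of hydrogen, compound 3

The compounds below may be only part of what the source reports. "The series", "measured", "known", "first", "only" and "open" are said of these compounds alone.

Among the compounds with values here, in a functional assay on HUVEC cells (Homo sapiens) for antiproliferative activity (on this read-out lower numbers stand for stronger inhibition and higher numbers for weaker inhibition), the series holds one number so far: compound 1 (`CONC(=O)c1cccc(CSc2cnc(Nc3ccccn3)s2)c1`) gives 110 nM as its result. Compound 2 (`CNC(=O)c1cccc(NCc2cnc(Nc3ccccn3)s2)c1`) has no number to compare, since the entry for compound 2 reads "not determined" (no result reported) without a value. Compound 3 (`CNC(=O)c1ccc(F)c(NCc2cnc(Nc3ccccn3)s2)c1`) is still unmeasured. The step to follow is fluoro in place of hydrogen on an aromatic carbon and it sits on an aromatic carbon, ortho to a large group and para to a methylcarbamoyl group. Within the data shown here, no measured pair shows what such a step does in this assay so the expectation is a change no larger than the usual scatter, in neither direction. Among the measured compounds shown here, the only available anchor is compound 1 at 110 nM and the estimate leans on that single number. For compound 3 the estimated value is 80 nM with an expected range of 20 nM to 350 nM as a working figure.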

Compound 3, half-maximal inhibitory concentration: 20 nM
Compound 3: the middle estimate sits 4.0-fold (0.60 log units) above what was measured; measured number inside the range.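

Compound 2 holds no number in this assay so the step to compound 3 cannot be read. The compounds shown leave open what fluoro in place of hydrogen does on this read-out. Nothing shown offers an explanation for the result of compound 3.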